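Replacing a basic side chain with an aryl amide

The source may report more compounds than this note shows. Statements on the series, on what has been measured and on what is new or still open speak of the compounds shown alone.

Three compounds share one core and differ only in the group attached to the amide nitrogen. Compound 1 `CCn1c(C(=O)NCCCN(C)C)ccc1C(CC)(CC)c1ccc(OCC(O)C(C)(C)C)c(C)c1` gives 197 nM in an assay on isolated protein for binding affinity to vitamin D3 receptor (Homo sapiens), with a stated time of 4 h; a lower number here means a stronger inhibitor, a higher number a weaker inhibitor. Compound 2 `CCN(CC)CCCNC(=O)c1ccc(C(CC)(CC)c2ccc(OCC(O)C(C)(C)C)c(C)c2)n1CC` gives 71.1 nM, and compound 3 `CCn1c(C(=O)NCCN)ccc1C(CC)(CC)c1ccc(OCC(O)C(C)(C)C)c(C)c1` gives 194 nM. Among these three numbers compound 3 stands second highest: its gap to compound 1 is within the scatter, while compound 2 sits clearly lower, as the step of a 2.7-fold higher number from compound 2 to compound 3 (0.44 log units; beyond the scatter) shows. The other steps were a 2.8-fold lower number from compound 1 to compound 2 (0.44 log units; beyond the scatter) and a 1.0-fold lower number from compound 1 to compound 3 (0.01 log units; within the scatter).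

Compound 4 `CCOc1ccc(NC(=O)c2ccc(C(CC)(CC)c3ccc(OCC(O)C(C)(C)C)c(C)c3)n2CC)cc1` is not yet measured. The change from compound 3 is 4-ethoxyphenyl in place of 2-aminoethyl on an amide-type nitrogen: the 2-aminoethyl group leaves and a 4-ethoxyphenyl enters, bringing a ring and removing a hydrogen-bond donor. For the measured compounds named here, none of the measured steps swaps a chain for a ring, so they bear on this change only loosely; they show that alterations at this amide nitrogen moved the value by no more than a modest amount. For compound 4 a step of about a 1.1-fold higher number from compound 3 to compound 4 (0.05 log units; within the scatter) is expected, essentially none beyond the scatter. The estimate for compound 4 is 220 nM, with a range from 70 nM to 700 nM.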

Compound 4, half-maximal inhibitory concentration: 9250 nM
Compound 4: middle estimate off by 42-fold (1.62 log units), on the low side; measured number outside the range, above it.
By their numbers in this assay, from the lowest: compound 2; then compounds 3 and 1 (each within the scatter of the next); then compound 4.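

Among the chains carrying an amine, changes at this amide nitrogen moved the number only modestly, but 4-ethoxyphenyl in place of 2-aminoethyl gives a 48-fold higher number from compound 3 to compound 4 (1.68 log units; beyond the scatter) and marks a far sharper limit on what this position accepts. The other two chains give the same picture: a 47-fold higher number from compound 1 to compound 4 (1.67 log units; beyond the scatter) and a 130-fold higher number from compound 2 to compound 4 (2.11 log units; beyond the scatter) are both large, so the loss of binding does not depend on which of these chains is the point of comparison. Nothing given here explains the loss.

The compounds shown leave open whether the ring alone or its ethoxy group goes with this loss, which plain phenyl on the same nitrogen would help to separate. They also leave open whether a ring can be accepted when it carries an amine, as in 4-(2-aminoethyl)phenyl.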